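One More Methyl at the Low End

The source may hold more compounds than are shown below. What is called first, only, known or untested is meant among the compounds shown, and "the series" means these compounds.

In an ADME assay for permeability, using PAMPA, with a stated time of 4 h (a lower number here means that the compound crosses the layer more slowly, a higher number that the compound crosses the layer faster), compound 1 `Cn1c(COc2cccc(C(=O)O)c2)nc2ccc(Oc3ccc(Cl)cn3)cc21` gives 16.2 10^-6 cm/s, compound 2 `Cn1c(COc2cccc(C(=O)O)c2)nc2ccc(Oc3ncccc3Cl)cc21` gives 8.1 10^-6 cm/s, and compound 3 `Cc1ccnc(Oc2ccc3nc(COc4cccc(C(=O)O)c4)n(C)c3c2)c1` gives 3.5 10^-6 cm/s, the lowest of the three. Compound 4 `Cc1ccc(C)c(Oc2ccc3nc(COc4cccc(C(=O)O)c4)n(C)c3c2)n1` carries 3,6-dimethylpyridin-2-yl in place of 4-methylpyridin-2-yl on an oxygen on an aromatic ring. The closest guide is the swap of 3-chloropyridin-2-yl for 4-methylpyridin-2-yl, which gave a 2.3-fold lower number from compound 2 to compound 3 (0.36 log units; beyond the scatter). The swap of 5-chloropyridin-2-yl for the same group gave a 4.6-fold lower number from compound 1 to compound 3 (0.67 log units; beyond the scatter). Neither step involves a dimethyl group, so this guide is loose. The expected change is a modest rise, a 2.1-fold higher number from compound 3 to compound 4 (0.33 log units; beyond the scatter). Compound 4 is estimated at 7.5 10^-6 cm/s, within a range from 3.2 10^-6 cm/s to 17 10^-6 cm/s.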

Compound 4, apparent permeability: 11 10^-6 cm/s
Compound 4: middle estimate off by 1.5-fold (0.17 log units), on the low side, within the range that was stated.
By their numbers in this assay, from the lowest: compound 3; then compounds 2, 4 and 1 (each within the scatter of the next).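

With 3,6-dimethylpyridin-2-yl on the oxygen, this assay shows a 3.1-fold higher number from compound 3 to compound 4 (0.50 log units; beyond the scatter), so this swap of a 4-methylpyridin-2-yl group moves the read-out beyond the scatter. The chlorinated compounds do not separate from the new one, with a 1.4-fold higher number from compound 2 to compound 4 (0.13 log units; within the scatter) and a 1.5-fold lower number from compound 1 to compound 4 (0.17 log units; within the scatter), leaving compound 3 alone at the low end. Nothing measured here gives a reason for the step. Still open, on these data alone, is which of the two methyl groups carries the step, and how an amine or a methoxy group in place of a methyl would read.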